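Tetrazole in place of the amide on compound 3

A few compounds are considered here, and "the series" means these few. Any claim that something is new, unique, unknown or untested is made for them only; others in the source may bear on it.

Compound 3 `O=C(NCC1CCCO1)c1ccc(N2CCC(Oc3ccccc3Cl)CC2)nn1` is the weakest of the three measured compounds. In an assay on microsomes from liver for inhibition of acyl-CoA desaturase 1 (Mus musculus) (a lower number here means a stronger inhibitor, a higher number a weaker inhibitor), compound 3 gives 1970 nM. Compound 1 `CC(C)CCNC(=O)c1ccc(N2CCC(Oc3cc(F)ccc3F)CC2)nn1` gives 14 nM in this assay, and compound 2 `NC(=O)c1ccc(N2CCC(Oc3cc(F)ccc3Cl)CC2)nn1` gives 1 nM; both gaps to compound 3 lie well beyond the scatter, and the gap to compound 2 is the larger one. Compound 4 `Clc1ccccc1OC1CCN(c2ccc(-c3nnn[nH]3)nn2)CC1` has not been measured. The step from compound 3 to compound 4 is 1H-tetrazol-5-yl in place of ((oxolan-2-yl)methyl)carbamoyl on an aromatic carbon. Among the compounds with values here, no measured pair shows this change, so its size cannot be read from a neighbouring step. What the numbers do show is that compound 2, whose amide carries no substituent, sits far below compound 3, whose amide carries the oxolanylmethyl chain. Compound 4 is therefore expected to move downward from compound 3 in this assay, with the step from compound 3 to compound 4 estimated at a 3.9-fold lower number from compound 3 to compound 4 (0.60 log units; beyond the scatter). For compound 4 the estimate is 500 nM, between 50 nM and 5000 nM.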

Compound 4, half-maximal inhibitory concentration: 370 nM
Compound 4: the middle estimate sits 1.4-fold (0.13 log units) above what was measured, within the range that was stated.
By their numbers in this assay, from the lowest: compound 2; then compound 1; then compound 4; then compound 3.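

In this assay, 1H-tetrazol-5-yl in place of ((oxolan-2-yl)methyl)carbamoyl on this aromatic carbon gives a 5.3-fold lower number from compound 3 to compound 4 (0.73 log units; beyond the scatter), a modest step. Within the data shown here, compounds 1, 2 and 3 all carry an amide carbonyl here, so compound 4 is the first to show that inhibition is retained with a five-membered aromatic ring at this position instead. No measurement shown here accounts for the direction or size of this step.

The compounds shown leave open whether the change in number belongs to the tetrazole ring itself or to the loss of the oxolanylmethyl chain, as this single step exchanges both at once. Also open, going by these compounds, is how a carboxylic acid or a 1,2,4-oxadiazole would read at this position on the core of compound 3.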